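Restoring a hydroxyl arm to an inactive analogue

This account rests on a few compounds, and the source may have more. Where it says the series, first, only, none or still open, it means among the compounds named here.

Measured compounds:
- compound 1, `CCCCCCCCc1ccc(CCC(N)(CO)CCO)cc1`: 0.12 mg/kg
- compound 2, `CCCCCCCCc1ccc(CCC(N)(CO)CCCO)cc1`: 0.021 mg/kg
- compound 3, `CCCCCCCCc1ccc(CCC(C)(N)CCO)cc1`: > 10 mg/kg

These three compounds share one core and differ only in the groups around the amine. In a functional assay on the whole organism (spleen, spleen) with Rattus norvegicus as the target (on this read-out lower numbers stand for an effect already at smaller amounts and higher numbers for an effect only at larger amounts of compound), compound 1 gives 0.12 mg/kg. Compound 2 gives 0.021 mg/kg, the step being a 5.7-fold lower number from compound 1 to compound 2 (0.76 log units; beyond the scatter). For compound 3 the assay gives only a limit, > 10 mg/kg, as noted in the limit of > 10 mg/kg in this assay, at which 1 of the 3 values shown sits; compound 3 therefore stands at the weak end of what is shown, with no number attached to it.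

Compound 4, `CCCCCCCCc1ccc(CCC(N)(CCO)CCO)cc1`, has not yet been measured. It differs from compound 3 by hydroxymethyl in place of hydrogen on a saturated chain carbon, two bonds along the chain from an amine nitrogen. The reverse kind of change is seen in the measured step of an at least 83-fold higher number from compound 1 to compound 3 (1.92 log units; beyond the scatter), where taking a hydroxy group away pushed the number up to the limit. Putting a hydroxyl-bearing arm back is expected to undo much of that shift, so a large step down in number is expected for compound 4, roughly an at least 100-fold lower number from compound 3 to compound 4 (2.00 log units; beyond the scatter). The estimate for compound 4 in this assay is 0.1 mg/kg, with a range from 0.02 mg/kg to 0.5 mg/kg.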

Compound 4, dose for 50% inhibition: > 10 mg/kg
Compound 4: only a limit was reported (the forecaster's own chance of this, stated with the estimate: 10%); at least 100-fold (2.00 log units) between middle value and limit.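

Replacing the methyl of compound 3 with a 2-hydroxyethyl arm does not by itself restore activity: in this assay, compound 4 gives > 10 mg/kg, which is again a limit. The comparisons with the two active compounds show an at least 83-fold higher number from compound 1 to compound 4 (1.92 log units; beyond the scatter) and an at least 470-fold higher number from compound 2 to compound 4 (2.67 log units; beyond the scatter), so a hydroxyl-bearing arm at this position is not enough; among these four compounds, only compound 1 and compound 2 carry a hydroxymethyl arm, and only they give a number. The step between the two inactive compounds, compound 3 and compound 4, cannot be read, because both stand at the same limit: the limit of > 10 mg/kg in this assay, at which 2 of the 4 values shown sit.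

As far as these compounds go, it remains open whether another small group on this carbon, such as an aminomethyl or a carboxylic acid, could take the place of the hydroxymethyl arm. Also open, from the compounds shown here alone, is whether a longer chain on the other arm, such as 4-hydroxybutyl, would keep the activity seen when compound 2 pairs a hydroxymethyl arm with a longer hydroxyl-bearing chain than compound 1 has.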